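This account rests on a few compounds, and the source may have more. Where it says the series, first, only, none or still open, it means among the compounds named here.

Compound 3 `CC1CCN(c2nc(C(F)(F)F)ccc2CNC(=O)C(C)c2ccc(NS(N)(=O)=O)c(F)c2)CC1` gives 2.7 nM in an assay on cells for antagonist activity at transient receptor potential cation channel subfamily V member 1 (Homo sapiens), read by FLIPR and calcium flux, with a stated time of 15 min; a higher number here means a weaker inhibitor, a lower number a stronger inhibitor. Compound 1 `CC1CCN(c2nc(C(F)(F)F)ccc2CNC(=O)C(C)c2ccc(NS(C)(=O)=O)c(Br)c2)CC1` gives 3.2 nM in this assay, and compound 2 `CCS(=O)(=O)Nc1ccc(C(C)C(=O)NCc2ccc(C(F)(F)F)nc2N2CCC(C)CC2)cc1F` gives 4.4 nM. Within the data shown here, the one measured step, a 1.6-fold lower number from compound 2 to compound 3 (0.21 log units; within the scatter), lies within the scatter, so compound 3 stands with the lowest number of the three but cannot be separated from compound 1 or compound 2 on these data.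

Compound 4 `CC1CCN(c2nc(C(F)(F)F)ccc2CNC(=O)C(C)c2ccc(N(C)S(C)(=O)=O)c(F)c2)CC1` is the unmeasured compound. It differs from compound 3 by methyl(methylsulfonyl)amino in place of sulfamoylamino on an aromatic carbon. Among the measured compounds shown here, the measured step from compound 2 to compound 3 changed only the group on the sulfonyl sulfur and left the nitrogen bearing its hydrogen; no measured step changes what sits on that nitrogen, and no measured compound lacks the hydrogen-bond donors that leave here. The scatter-sized step a 1.6-fold lower number from compound 2 to compound 3 (0.21 log units; within the scatter) therefore bears on the sulfonyl side of the change only. With the nitrogen change unsupported by any measured pair, compound 4 is expected to give a higher number in this assay, a step of a 5.6-fold higher number from compound 3 to compound 4 (0.74 log units; beyond the scatter), and its value is estimated at 15 nM within a range from 4 nM to 60 nM.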

Compound 4, inhibition constant: 55.5 nM
Beside the measured number, compound 4's estimate is 3.7-fold (0.57 log units) below it; the range from low to high includes it.
By their numbers in this assay, from the lowest: compounds 3, 1 and 2 (each within the scatter of the next); then compound 4.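

Compound 4 shows that the group on this aromatic carbon, ortho to a fluoro group, is not free to change in this assay: methyl(methylsulfonyl)amino in place of sulfamoylamino gives a 21-fold higher number from compound 3 to compound 4 (1.31 log units; beyond the scatter), and in place of (ethylsulfonyl)amino it gives a 13-fold higher number from compound 2 to compound 4 (1.10 log units; beyond the scatter), whereas the change on the sulfonyl sulfur alone gave only a 1.6-fold lower number from compound 2 to compound 3 (0.21 log units; within the scatter). Among these compounds, the nitrogen bears a hydrogen in compound 2 and compound 3 but a methyl in compound 4, so the first large steps in this set come with a change on that nitrogen. No measurement here explains the loss.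

The compounds shown leave open whether the methyl on the nitrogen alone accounts for these steps, apart from the change on the sulfonyl sulfur. From the compounds shown here alone, how an ethyl group on that nitrogen, or a carboxylic acid on this aromatic carbon, would read also remains open.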